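The source may report more compounds than this note shows. Statements on the series, on what has been measured and on what is new or still open speak of the compounds shown alone.

Values so far in an ADME assay on HepG2 cells (Homo sapiens) for cytotoxicity, read by MTT assay, with a stated time of 24 h (a higher number here means that more compound is tolerated, a lower number that less compound is tolerated), are these:

Compound 1 `Cc1ccc(-c2c([N+](=O)[O-])nc3n2CC(C)O3)s1` gives > 250000 nM as a limit
Compound 2 `CC1Cn2c(nc([N+](=O)[O-])c2-c2ccc(OC(F)(F)F)cc2)O1` gives > 184000 nM as a limit
Compound 3 `CC1Cn2c(nc([N+](=O)[O-])c2C#Cc2ccc(CO)cc2)O1` gives 9000 nM as a number

The record for this series is thin. Compound 1 reaches only a limit at > 250000 nM in this assay and gives no exact figure. Compound 2 likewise reaches only a limit at > 184000 nM in that assay. Among the measured compounds shown here, compound 3 stands alone with a true number of 9000 nM and so is the only compound here with a measured position.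

Compound 4 `CC1Cn2c(nc([N+](=O)[O-])c2C#Cc2ccccc2)O1` has not yet been measured. It carries hydrogen in place of hydroxymethyl on an aromatic carbon of a six-membered aromatic ring of carbon only, para to a large group hydrogen in place of hydroxymethyl on an aromatic carbon and is otherwise the same as compound 3.

For the measured compounds named here, no measured pair in the set isolates a change of this kind, so the size of the step cannot be read from the data. The expectation rests on compound 3 at 9000 nM as the sole anchor, and no shift beyond the usual scatter is assumed in either direction. The expected result is a 1.1-fold higher number from compound 3 to compound 4 (0.05 log units; within the scatter) and this estimate stays within that scatter. For compound 4 the estimated value is 10000 nM with an expected range from 3000 nM to 40000 nM in this assay when it is measured.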

Compound 4, half-maximal cytotoxic concentration: 5400 nM
Estimate against measurement, compound 4: 1.9-fold (0.27 log units) above; measured number inside the range.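

In this assay, placing hydrogen in place of hydroxymethyl on an aromatic carbon, para to a large group, gives a 1.7-fold lower number from compound 3 to compound 4 (0.22 log units; within the scatter). Among the compounds shown here, this is the first pair that differs in one place and has an exact number on both sides, so it gives the first direct reading at this position, and the two compounds cannot be told apart in this assay. Compound 3 therefore does not owe its measured number to the hydroxymethyl group, since compound 4 lacks that group and its value remains within the scatter of the value for compound 3, while nothing measured here offers a reason for the small step.

The compounds shown leave open whether a different group at this same place, such as an amine, a carboxylic acid or a longer chain, would move the number beyond the scatter. They also leave open what separates compound 3 and compound 4 from compound 1 and compound 2, which reach only limits and differ from them in more than one place.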